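The compounds below may be only part of what the source reports. "The series", "measured", "known", "first", "only" and "open" are said of these compounds alone.

Compound 1 `O=CNC[C@H]1CN(c2ccc(-n3cc(-c4ccccn4)cn3)c(F)c2)C(=O)O1` gives 1.19 in a physicochemical assay for lipophilicity, read by HPLC, measured as octanol-water partition; a higher number here means a more lipophilic compound, a lower number a more polar compound. Compound 2 `CS(=O)(=O)NC[C@H]1CN(c2ccc(-n3cc(-c4ccccn4)cn3)c(F)c2)C(=O)O1` gives 1.38 in this assay, the higher of the two numbers, and the step of a number 0.19 log units higher from compound 1 to compound 2 (within the scatter) stays within the scatter. Compound 3 `O=C1O[C@@H](CNC(=O)C(F)(F)F)CN1c1ccc(-n2cc(-c3ccccn3)cn2)c(F)c1` differs from compound 2 in one place: (trifluoromethyl)carbonyl in place of methylsulfonyl on an amine nitrogen. Among the measured compounds shown here, the only measured step, a number 0.19 log units higher from compound 1 to compound 2 (within the scatter), swapped groups on that same nitrogen without moving the number beyond the scatter, so it offers only a loose guide here. For compound 3 a modest rise is expected, a number 0.47 log units higher from compound 2 to compound 3 (beyond the scatter), giving an estimated 1.85 in this assay, with a range from 1.45 to 2.25.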

Compound 3, partition coefficient: >= 1.78
Compound 3 gave a limit, no number; the forecaster's own chance of this, stated with the estimate: 0%; the middle value does not contradict the limit.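

On this amine nitrogen, a swap of groups can move the number beyond the scatter: in this assay, (trifluoromethyl)carbonyl in place of methylsulfonyl gives a number at least 0.40 log units higher from compound 2 to compound 3 (beyond the scatter). Trifluoromethyl in place of hydrogen on the carbonyl carbon likewise gives a number at least 0.59 log units higher from compound 1 to compound 3 (beyond the scatter). Compound 3 gives a limit of the assay, not a number: the limit of >= 1.78 in this assay, at which 1 of the 3 values shown sits.

From the compounds shown here alone, the full size of both steps therefore stays open. Also open, going by these compounds, is where an acetyl group, with a plain methyl on the carbonyl, would fall on this nitrogen, and so whether the fluorine atoms account for the rise.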